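Replacing the aryl amide group in a small cytotoxicity series

The source may report more compounds than this note shows. Statements on the series, on what has been measured and on what is new or still open speak of the compounds shown alone.

Of the compounds shown here, three built on a shared core have been tested in a functional assay on PC-3 cells (Homo sapiens) for cytotoxicity; a lower number here means a stronger inhibitor of growth, a higher number a weaker inhibitor of growth. Compound 1 `CCCCCCCCC(=O)N1c2ccccc2CC1C(=O)Nc1ccc(C(F)(F)F)cc1` gives 1860 nM. Compound 2 `CC(C)(C)OC(=O)N1c2ccccc2CC1C(=O)Nc1cc(C(F)(F)F)ccc1C(F)(F)F` gives 838 nM. Compound 3 `CC(NC(=O)OC(C)(C)C)C(=O)N1c2ccccc2CC1C(=O)Nc1ccc(C(C)(F)F)cc1` gives 6260 nM, the highest of the three numbers; its gap to compound 1 and its larger gap to compound 2 both lie beyond the scatter of the measurement, so compound 3 is the weakest growth inhibitor of the three as it stands.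

Compound 4 `CC(NC(=O)OC(C)(C)C)C(=O)N1c2ccccc2CC1C(=O)Nc1cc(Cl)cc(Cl)c1` differs from compound 3 in one place: 3,5-dichlorophenyl in place of 4-(1,1-difluoroethyl)phenyl on an amide-type nitrogen. The rest of the molecule, including the carbamate-bearing side chain on the core, is unchanged. Among the measured compounds shown here, no measured pair in this set shows exactly this exchange, so its size cannot be read off directly. What the numbers do show is that the two compounds carrying trifluoromethyl groups on the aryl amide, compound 1 and compound 2, both sit at lower numbers than compound 3.

On that basis compound 4 is expected to move toward a lower number, by a step of about a 2.1-fold lower number from compound 3 to compound 4 (0.32 log units; beyond the scatter), though a change within the scatter cannot be ruled out. The estimate for compound 4 in this assay is 3000 nM, with a range from 800 nM to 12000 nM.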

Compound 4, concentration for 50% growth inhibition: 4430 nM
Beside the measured number, compound 4's estimate is 1.5-fold (0.17 log units) below it, within the range that was stated.
By their numbers in this assay, from the lowest: compound 2; then compound 1; then compounds 4 and 3 (each within the scatter of the next).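

In this assay, among the compounds shown here, the exchange of 4-(1,1-difluoroethyl)phenyl for 3,5-dichlorophenyl on the amide-type nitrogen gives a step (a 1.4-fold lower number from compound 3 to compound 4 (0.15 log units; within the scatter)), and this is the first direct reading of any change at this position. With the rest of the molecule held the same, these two aryl groups cannot be told apart in this read-out, even though they carry different halogens at different places on the ring. Nothing in the data speaks to why the two groups read alike.

Going by these compounds, whether this position stays as unresponsive for groups of a different kind remains open, for instance a phenyl ring bearing an amine or a carboxylic acid, or a saturated ring such as cyclohexyl in place of the phenyl. It is also unknown whether the same exchange would give a similar result on a different side chain, such as the nonanoyl chain of compound 1, which differs from compound 3 and compound 4 in more than one place.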